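A few compounds are considered here, and "the series" means these few. Any claim that something is new, unique, unknown or untested is made for them only; others in the source may bear on it.

Measured compounds:
compound 1, `N/C(=N\NC(=S)N1CCOCC1)c1ccccn1`, 66.7%
compound 2, `Cc1cccc(/C(N)=N/NC(=S)N2CCSCC2)n1`, 22.5%
compound 3, `Cc1ccnc(/C(N)=N/NC(=S)N2CCSCC2)c1`, 62.5%

These three share one core and were tested in a functional assay on MCF7 cells (Homo sapiens) for cytotoxicity, read by MTT assay, with a stated time of 72 h, tested at 10 uM; on this read-out higher numbers stand for more inhibition of growth at the one concentration tested and lower numbers for less inhibition of growth. Compound 3 stands second highest of the three numbers: compound 1 lies nearest, a difference within the scatter, while compound 2 lies furthest, a difference beyond the scatter. Compound 4, `N/C(=N\NC(=S)N1CCSCC1)c1ccccn1`, differs from compound 3 in one place: hydrogen in place of methyl on an aromatic carbon. Within the data shown here, no pair of measured compounds differs in a single place, so no measured step is available to set the size of this change. Since compound 1, which also carries no methyl on that ring, gives 66.7%, the expected step from compound 3 to compound 4 is a number 0.5 percentage points higher from compound 3 to compound 4 (within the scatter), none beyond the scatter. For compound 4 the estimated value is 63%, with a range from 46% to 78%.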

Compound 4, percent growth inhibition at one concentration: 54.3%
Beside the measured number, compound 4's estimate is 8.7 percentage points above it, within the range that was stated.
By their numbers in this assay, from the lowest: compound 2; then compounds 4, 3 and 1 (each within the scatter of the next, the first and the last beyond it).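

In this assay, hydrogen in place of the methyl opposite the ring nitrogen gives a number 8.2 percentage points lower from compound 3 to compound 4 (within the scatter) and so shows no clear loss or gain at this position. The same exchange at the other methyl position gives a number 31.8 percentage points higher from compound 2 to compound 4 (beyond the scatter) and shows that a ring methyl does not act alike at every carbon. Thiomorpholin-4-yl in place of morpholin-4-yl gives a number 12.4 percentage points lower from compound 1 to compound 4 (beyond the scatter) as the first sign that this ring also counts.

From the compounds shown here alone, whether ethyl, methoxy or an amine on that aromatic carbon would fit remains open. Nothing available explains any of these steps.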